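The compounds below may be only part of what the source reports. "The series", "measured", "known", "first", "only" and "open" are said of these compounds alone.

Measured so far in an in vitro ADME assay on microsomes from liver (Homo sapiens) for metabolic stability, using NADPH; on this read-out lower numbers stand for slow clearance and higher numbers for fast clearance:
- compound 1 `CC(C)(CO)CNC(=O)c1cc2cc(C#N)ccc2n1Cc1cc(Cl)cc(Cl)c1` gives 103 mL.min-1.g-1
- compound 2 `CC(C)(O)CCNC(=O)c1cc2cc(C#N)ccc2n1Cc1cccc(OC(F)(F)F)c1` gives 9 mL.min-1.g-1

Compound 2 holds the lower of the two numbers, and the gap to compound 1 lies beyond the scatter. Among the measured compounds shown here, compound 3 `CC(O)C1(CNC(=O)c2cc3cc(C#N)ccc3n2Cc2cccc(OC(F)(F)F)c2)CCCC1` differs from compound 2 by a group of 8 heavy atoms (7 carbon, 1 oxygen; one five-membered non-aromatic ring of carbon only) in place of a group of 5 heavy atoms (4 carbon, 1 oxygen; no ring), on a saturated chain carbon bound to an amide-type nitrogen and has no measurement yet. For the measured compounds named here, no measured pair isolates this change, so the expectation is loose. With compound 1 at 103 mL.min-1.g-1 as the only upper reference, a rise beyond the scatter in this assay is expected, though one that stays short of that number. The expected change is a 3.3-fold higher number from compound 2 to compound 3 (0.52 log units; beyond the scatter) as estimated here. For compound 3 the estimate is 30 mL.min-1.g-1 with an expected range from 12 mL.min-1.g-1 to 80 mL.min-1.g-1 in this read-out.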

Compound 3, intrinsic clearance in microsomes: 505 mL.min-1.g-1
Estimate against measurement, compound 3: 17-fold (1.23 log units) below; measured number outside the range, above it.
By their numbers in this assay, from the lowest: compound 2; then compound 1; then compound 3.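

Changes at this place on a saturated chain carbon bound to an amide-type nitrogen are not neutral in this assay: replacing the 2-hydroxy-2-methylpropyl group with the larger group holding one five-membered non-aromatic ring of carbon only gives a 56-fold higher number from compound 2 to compound 3 (1.75 log units; beyond the scatter). This pair shows that the change in this one place can alone produce a large step. Nothing measured here accounts for its size. From the compounds shown here alone, whether the step follows the ring or the added carbon atoms remains open. A cyclopropane ring or an amine in this group would give further comparisons.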